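The source may report more compounds than this note shows. Statements on the series, on what has been measured and on what is new or still open speak of the compounds shown alone.

Compound 2 `O=C(Nc1noc2cccnc12)N1CCN(Cc2cccc(Oc3ccc(Cl)cc3)c2)CC1` gives the lowest of the two numbers seen so far: in an assay on isolated protein for inhibition of Fatty-acid amide hydrolase 1 (Homo sapiens), with a stated time of 60 min (a higher number here means a weaker inhibitor, a lower number a stronger inhibitor), compound 2 gives 13 nM, while compound 1 `O=C(Nc1cccc2cn[nH]c12)N1CCN(Cc2cccc(Oc3ccc(Cl)cc3)c2)CC1` gives 1300 nM in this assay. Compound 3 `O=C(Nc1cccc2nccn12)N1CCN(Cc2cccc(Oc3ccc(Cl)cc3)c2)CC1` differs from compound 2 by a group of 9 heavy atoms (7 carbon, 2 nitrogen; one five-membered aromatic ring with 2 hetero atoms, one six-membered aromatic ring with 1 hetero atom) in place of a group of 9 heavy atoms (6 carbon, 2 nitrogen, 1 oxygen; one five-membered aromatic ring with 2 hetero atoms, one six-membered aromatic ring with 1 hetero atom), on an amide-type nitrogen. Among the compounds with values here, the only step that bears on this is a 100-fold lower number from compound 1 to compound 2 (2.00 log units; beyond the scatter), which swapped the same region of the molecule, yet neither end of that step matches the group entering here, so the direction for compound 3 remains uncertain. Because compound 2 sits at 13 nM, compound 3 is expected to lose some potency, with the step of a 7.7-fold higher number from compound 2 to compound 3 (0.89 log units; beyond the scatter), giving an estimated 100 nM within 20 nM to 600 nM.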

Compound 3, half-maximal inhibitory concentration: 2.7 nM
Estimate against measurement, compound 3: 37-fold (1.57 log units) above; the measured number lies below the stated range.
By their numbers in this assay, from the lowest: compound 3; then compound 2; then compound 1.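

Inhibition grows stronger again when the oxygen-bearing group gives way to the group of carbon and nitrogen only, with a 4.8-fold lower number from compound 2 to compound 3 (0.68 log units; beyond the scatter), so the oxygen of compound 2 is not required at this amide-type nitrogen. Within the data shown here, the group in compound 1 has the same carbon and nitrogen count as the one in compound 3, yet the data show a 480-fold lower number from compound 1 to compound 3 (2.68 log units; beyond the scatter), so atom count alone does not set the strength here. Nothing measured here explains either step. On these data alone, whether a fluorine or methoxy group on the entering group would keep this strength remains open.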